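A few compounds are considered here, and "the series" means these few. Any claim that something is new, unique, unknown or untested is made for them only; others in the source may bear on it.

Measured in a functional assay (aorta) with Rattus norvegicus as the target; a lower number here means that less compound is needed, a higher number that more compound is needed for the effect:
- compound 1 `CCNC1=NS(=O)(=O)c2cc(F)ccc2N1`: > 300 uM (a limit of the assay, not a number)
- compound 2 `O=S1(=O)NC(NC2CCC2)=Nc2ccc(F)cc21`: 71.8 uM
- compound 3 `CCNC1=NS(=O)(=O)c2cc(Cl)ccc2N1`: 39.9 uM

Compound 3 at 39.9 uM and compound 2 at 71.8 uM lie within the scatter of each other. The remaining result is the limit of compound 1, noted as the limit of > 300 uM in this assay, at which 1 of the 3 values shown sits.

The next compound is compound 4 `O=S1(=O)N=C(NC2CCC2)Nc2ccc(Cl)cc21`, reached from compound 3 by cyclobutyl in place of ethyl on an amine nitrogen.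

Among the compounds with values here, the one measured step, an at least 7.5-fold lower number from compound 1 to compound 3 (0.87 log units; beyond the scatter), is a change of chloro in place of fluoro, so it does not measure this change directly. The closer guide is the fluoro pair. Compound 1, with ethylamino, gives only a limit. Compound 2, with cyclobutylamino, gives a number, 71.8 uM, so a modest move to a lower number is expected in this assay, though this rests on that single pair.

For compound 4 the estimated value is 15 uM, with an expected range of 4 uM to 55 uM.
The expected step is a 2.7-fold lower number from compound 3 to compound 4 (0.42 log units; beyond the scatter).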

Compound 4, concentration for half-maximal effect: 34.9 uM
The estimate for compound 4 lay 2.3-fold (0.37 log units) below the measured number, and the stated range covers the measured number.
By their numbers in this assay, from the lowest: compounds 4, 3 and 2 (each within the scatter of the next, the first and the last beyond it). At a limit, above all of these: compound 1.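

In this assay, within the data shown here, cyclobutyl in place of ethyl on an amine nitrogen gives a 1.1-fold lower number from compound 3 to compound 4 (0.06 log units; within the scatter) as the first reading of this change with a number at both ends. With chloro on the aromatic carbon, ethylamino and cyclobutylamino therefore cannot be told apart in this assay, and this rests on a single pair. Compound 1 is a limit of the assay, so the fluoro pair gives no size for the same change: the limit of > 300 uM in this assay, at which 1 of the 4 values shown sits.

From the compounds shown here alone, whether the flat result holds for a longer chain, an isopropyl group or a cyclopentyl group on the amine nitrogen remains open. Also open, going by these compounds, is whether bromo or methoxy on the aromatic carbon would change the response to this amine swap.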